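Benzyl in place of methyl: expected outcome for compound 4

The compounds below may be only part of what the source reports. "The series", "measured", "known", "first", "only" and "open" are said of these compounds alone.

Measured compounds:
Compound 1, `CCCn1cc2c(Nc3ccc(OC(F)(F)F)cc3)ncnc2n1`, gives > 10000 nM, a limit of the assay.
Compound 2, `FC(F)(F)Oc1ccc(Nc2ncnc3nn(Cc4cccnc4)cc23)cc1`, gives > 10000 nM, also a limit.
Compound 3, `CCn1cc2c(Nc3ccc(OC(F)(F)F)cc3)ncnc2n1`, gives > 10000 nM, again a limit.

In an ADME assay on BaF3 cells (Mus musculus) for cytotoxicity (on this read-out lower numbers stand for an effect already at smaller amounts and higher numbers for an effect only at larger amounts of compound), compound 3 therefore stands at a limit and not at a number. All three values shown share this position; (the limit of > 10000 nM in this assay, at which 3 of the 3 values shown sit). Compound 4, `FC(F)(F)Oc1ccc(Nc2ncnc3nn(Cc4ccccc4)cc23)cc1`, differs from compound 3 by phenyl in place of methyl on a saturated chain carbon bound to an aromatic nitrogen. The measured steps that bear on it are a step that the two limits leave unreadable from compound 2 to compound 3, a step that the two limits leave unreadable from compound 1 to compound 2 and a step that the two limits leave unreadable from compound 1 to compound 3; all three are unreadable, both ends standing at the limit. No readable step in this assay in either direction is thus indicated, and compound 4 is expected to stand at the limit as well. The estimate for compound 4 is 20000 nM, between 8000 nM and 60000 nM. This expected step, a step that the limit leaves unreadable from compound 3 to compound 4, lies within the scatter.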

Compound 4, half-maximal effective concentration: > 10000 nM
Compound 4: no number, only a limit; the forecaster's own chance of this, stated with the estimate: 85%; the middle value lies beyond the limit too.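

Compound 4 yields no readable step against compound 1, compound 2 or compound 3 in this assay, since all of these compounds stand at one limit: the limit of > 10000 nM in this assay, at which 4 of the 4 values shown sit.

As far as these compounds go, how far past that limit each of the four compounds lies, and so whether they differ at all, remains open.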